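The source may hold more compounds than are shown below. What is called first, only, known or untested is meant among the compounds shown, and "the series" means these compounds.

Working notes on the series.

Among the measured compounds shown here, compound 2 `COc1cccc(CNc2n[nH]c(-c3cccnc3Oc3cc(OC)cc(OC)c3)n2)c1` stands lowest of the two numbers so far in a functional assay on A-431 cells (Homo sapiens), tested at 0.1 uM (on this read-out higher numbers stand for more inhibition at the one concentration tested (going by the name of the read-out) and lower numbers for less inhibition), where compound 2 gives 32%. For the measured compounds named here, its only neighbour is compound 1 `COc1cccc(Nc2n[nH]c(-c3cccnc3Oc3cc(OC)cc(OC)c3)n2)c1`, for which this assay returns 83%; the step of a number 51 percentage points lower from compound 1 to compound 2 (beyond the scatter) is the one large move recorded, and it comes with 3-methoxybenzyl in place of 3-methoxyphenyl on a nitrogen on an aromatic ring.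

Compound 3 `COc1ccc(CNc2n[nH]c(-c3cccnc3Oc3cc(OC)cc(OC)c3)n2)cc1` differs from compound 2 as follows: 4-methoxyphenyl in place of 3-methoxyphenyl on a saturated chain carbon bound to a nitrogen on an aromatic ring. Going by the values given here, no measured step in the set touches a move of this kind; the one step available, from compound 1 to compound 2, concerns the link to the nitrogen and not the placing of the methoxy group, so it gives no direction for compound 3. The expectation for compound 3 is therefore a step of about no change at the digits printed from compound 2 to compound 3 (within the scatter), nothing beyond the scatter. Compound 3 is estimated at 32% in this assay, within 15% to 52%.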

Compound 3, a percentage reported as inhibition, at one concentration (the size of the read-out at that concentration, not a potency): 28%
Estimate against measurement, compound 3: 4 percentage points above; the measured number falls inside the stated range.
By their numbers in this assay, from the lowest: compounds 3 and 2 (each within the scatter of the next); then compound 1.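

In this assay, shifting the methoxy group with the benzyl link in place gives a number 4 percentage points lower from compound 2 to compound 3 (within the scatter), so the 3-methoxybenzyl and 4-methoxybenzyl groups cannot be told apart on this read-out. Set against the directly attached aryl group of compound 1, the second benzyl compound gives a number 55 percentage points lower from compound 1 to compound 3 (beyond the scatter), so the large drop seen with compound 2 recurs with the other methoxy placing and does not belong to one placing alone. No measurement here accounts for either step.

Still open, from the compounds shown here alone, is whether 4-methoxyphenyl attached directly to the nitrogen would read like compound 1, which would show if the methoxy placing matters without the saturated chain carbon. Also open, going by these compounds, is how a longer chain such as 2-phenylethyl, or a hydroxyl in place of the methoxy group, would read at this position.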